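The source may report more compounds than this note shows. Statements on the series, on what has been measured and on what is new or still open speak of the compounds shown alone.

Compound 1 `CC(C)(C)N(NC(=O)c1cccc(Cl)c1)C(=O)c1ccccc1Cl` and compound 2 `CC(C)(C)N(NC(=O)c1ccc(C#N)cc1)C(=O)c1ccccc1Cl` share one core and differ only in the aromatic ring attached to one of the two carbonyl carbons. In an assay on cells for agonist activity at ecdysone receptor (Bombyx mori), read by a luciferase reporter, with a stated time of 24 h (on this read-out higher numbers stand for an effect only at larger amounts of compound and lower numbers for an effect already at smaller amounts), compound 1 gives 155 nM, and compound 2 gives 603 nM. For the measured compounds named here, the single step between them, a 3.9-fold higher number from compound 1 to compound 2 (0.59 log units; beyond the scatter), shows that swapping the substituents on this ring shifts the read-out by a modest amount. On the two numbers available, compound 2 stands at the higher one, so a larger amount of it is needed for the same effect.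

Compound 3 `Cc1ccc(C(=O)NN(C(=O)c2ccccc2Cl)C(C)(C)C)cc1C` carries the next variation at the same place: 3,4-dimethylphenyl in place of 4-cyanophenyl on a carbonyl carbon. Going by the values given here, the only measured step that bears on this change is the one from compound 1 to compound 2, and it was modest. Among the compounds with values here, a dimethyl-substituted ring has not yet been seen, so the direction is uncertain, but the one known step suggests that ring changes here stay modest. For compound 3 in this assay the estimate is 200 nM, with a range from 50 nM to 800 nM, which would mean an expected step of a 3.0-fold lower number from compound 2 to compound 3 (0.48 log units; beyond the scatter).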

Compound 3, half-maximal effective concentration: 87.1 nM
Beside the measured number, compound 3's estimate is 2.3-fold (0.36 log units) above it; the range from low to high includes it.
By their numbers in this assay, from the lowest: compounds 3 and 1 (each within the scatter of the next); then compound 2.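

In this assay, the change to the 3,4-dimethylphenyl ring gives a 6.9-fold lower number from compound 2 to compound 3 (0.84 log units; beyond the scatter), so this position can move the read-out in both directions, and the rise seen with 4-cyanophenyl can be reversed by another ring. The second comparison gives a 1.8-fold lower number from compound 1 to compound 3 (0.25 log units; within the scatter), which places the 3,4-dimethylphenyl and 3-chlorophenyl rings level with each other, so these two different rings on the carbonyl carbon cannot be told apart here, while compound 2 stands apart from both by more than the scatter. No measurement shown here explains why these rings differ or match in this way.

For the compounds shown here, with only three rings, it remains open whether the nitrile itself or its place on the ring sets compound 2 apart, since compound 2 differs from the other two compounds in both respects. It is also unknown how this position would respond to a ring bearing an amine, a carboxylic acid or a longer chain such as butyl, or whether the small spread between compound 1 and compound 3 would hold for such groups.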